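This account rests on a few compounds, and the source may have more. Where it says the series, first, only, none or still open, it means among the compounds named here.

Compound 1 `CC(C)[C@@H]1NC(=O)[C@H](CCCNC(=N)N)NC(=O)CNC(=O)C[C@@H](C(=O)O)NC(=O)[C@@H](c2ccccc2)NC1=O` gives 115 nM in an assay on a protein complex for binding affinity to integrin alpha-5/beta-1 (Homo sapiens), read by ELISA; on this read-out higher numbers stand for weaker inhibition and lower numbers for stronger inhibition; compound 2 `CC(C)[C@H]1NC(=O)[C@H](CCCNC(=N)N)NC(=O)CNC(=O)C[C@@H](C(=O)O)NC(=O)[C@@H](c2ccccc2)NC1=O` gives 7.3 nM; compound 3 `N=C(N)NCCC[C@@H]1NC(=O)CNC(=O)C[C@@H](C(=O)O)NC(=O)[C@@H](c2ccccc2)NC(=O)[C@@H]2CCCN2C1=O` gives 111 nM.

Compound 1 holds the highest number of the three in this assay, with compound 3 within the scatter of it and compound 2 far beneath it. For the measured compounds named here, the only measured step, a 16-fold lower number from compound 1 to compound 2 (1.20 log units; beyond the scatter), turns on the fact that one of compounds 1 and 2 is drawn with a defined configuration and the other without, at the place where they differ and concerns a change of configuration rather than of any group. Compound 4 `N=C(N)NCCC[C@@H]1NC(=O)CNC(=O)C[C@@H](C(=O)O)NC(=O)[C@@H](c2ccccc2)NC(=O)[C@H](Cc2c[nH]c3ccccc23)NC1=O` differs from compound 1 by (1H-indol-3-yl)methyl in place of isopropyl on a saturated ring carbon. Going by the values given here, no measured step covers this exchange; the values of compound 1 and compound 3 show only that a different group at the same saturated ring carbon left the number close. Compound 4 is therefore expected near compound 1, at an estimated 100 nM (range 30 nM to 400 nM), the expected step being a 1.2-fold lower number from compound 1 to compound 4 (0.06 log units; within the scatter), within the scatter.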

Compound 4, half-maximal inhibitory concentration: 72 nM
Compound 4: the middle estimate sits 1.4-fold (0.14 log units) above what was measured; low and high end bracket the measured number.
By their numbers in this assay, from the lowest: compound 2; then compounds 4, 3 and 1 (each within the scatter of the next).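

Putting (1H-indol-3-yl)methyl in place of isopropyl on this saturated ring carbon gives a 1.6-fold lower number from compound 1 to compound 4 (0.20 log units; within the scatter) in this assay, so an aromatic group with a hydrogen-bond donor is accepted here. At this same carbon, the change of configuration in a 16-fold lower number from compound 1 to compound 2 (1.20 log units; beyond the scatter) moved the number beyond the scatter, whereas this change of group did not. The data offer no explanation for this tolerance.

From the compounds shown here alone, it remains open whether an amine or a carboxylic acid on this carbon would keep the number as close, and how (1H-indol-3-yl)methyl would fare in the opposite configuration.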